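The source may hold more compounds than are shown below. What is called first, only, known or untested is meant among the compounds shown, and "the series" means these compounds.

In a functional assay on GC3/C1 cells (Homo sapiens) for cytotoxicity, read by MTT assay, with a stated time of 6 days (a lower number here means a stronger inhibitor, a higher number a weaker inhibitor), compound 1 (`COc1ccccc1NC(=O)SC[C@H](NC(C)=O)C(=O)O`) gives > 200000 nM, which is a limit of the assay and not a number. Compound 2 (`CC(=O)N[C@@H](CSC(=O)Nc1cccc(Cl)c1)C(=O)O`) gives > 200000 nM, again only a limit. Compound 3 (`CC(=O)N[C@@H](CSC(=O)Nc1ccccc1)C(=O)O`) has not yet been measured, and it carries hydrogen in place of chloro on an aromatic carbon. Since compound 2 sits at the limit of > 200000 nM in this assay, at which 2 of the 2 values shown sit, the expected change is none beyond the usual scatter: a number no higher from compound 2 to compound 3 (the limit leaves the size open). The estimate for compound 3 is 200000 nM, with an expected range of 100000 nM to 400000 nM, and this assay will probably report only a limit again.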

Compound 3, half-maximal inhibitory concentration: 178000 nM
Beside the measured number, compound 3's estimate is 1.1-fold (0.05 log units) above it; low and high end bracket the measured number.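

In this assay, going by these compounds alone, compound 3 gives 178000 nM, the first true number here rather than a limit. Hydrogen in place of chloro gives an at least 1.1-fold lower number from compound 2 to compound 3 (0.05 log units; that floor lies within the scatter), and hydrogen in place of methoxy gives an at least 1.1-fold lower number from compound 1 to compound 3 (0.05 log units; that floor lies within the scatter). Each step starts from a limit, so its true size stays open: the limit of > 200000 nM in this assay, at which 2 of the 3 values shown sit.

As far as these compounds go, whether an amine or a nitrile on this aromatic carbon would give a clearly lower number in this assay remains open. So does whether chloro or methoxy at other ring carbons would matter.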